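Diaryl ether series: tert-butyl for methoxy on the phenoxy ring

This account rests on a few compounds, and the source may have more. Where it says the series, first, only, none or still open, it means among the compounds named here.

Compound 2 `COc1ccc(Oc2ccc3c(NCCCNCc4cccc(OC)c4O)ccnc3c2)cc1` gives 317 10^-6 cm/s in an ADME assay for permeability, using PAMPA, with a stated time of 30 min, at pH 7.4; on this read-out higher numbers stand for higher permeability and lower numbers for lower permeability. Compound 1 `COc1ccc(Oc2ccc3c(NCCCNCc4cc(F)ccc4OC)ccnc3c2)cc1` gives 317 10^-6 cm/s in this assay, and no change at the digits printed from compound 1 to compound 2 (within the scatter). Compound 3 `COc1ccc(-c2ccc3c(NCCCNCc4cc(F)ccc4OC)ccnc3c2)cc1` gives 237 10^-6 cm/s; here a 1.3-fold lower number from compound 1 to compound 3 (0.13 log units; within the scatter). All three measured numbers thus lie within the scatter of one another, and compound 2 stands level with compound 1, with compound 3 close by.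

Compound 4 `COc1cccc(CNCCCNc2ccnc3cc(Oc4ccc(C(C)(C)C)cc4)ccc23)c1O` has not been measured in this assay. Against compound 2 the difference is: tert-butyl in place of methoxy on an aromatic carbon. Neither measured step covers this exchange. The step of a 1.3-fold lower number from compound 1 to compound 3 (0.13 log units; within the scatter) concerns the same 4-methoxyphenoxy part of the molecule and did not move the read-out beyond the scatter; the step of no change at the digits printed from compound 1 to compound 2 (within the scatter) concerns the group on the saturated chain carbon bound to an amine nitrogen and is uninformative for the phenoxy ring. Among the measured compounds shown here, nothing among the measured compounds indicates that a change on the phenoxy ring shifts this assay beyond its scatter, and the measured values already sit at a high level. The expected step is therefore a 1.1-fold lower number from compound 2 to compound 4 (0.04 log units; within the scatter), meaning no shift beyond the scatter. Compound 4 is estimated at 290 10^-6 cm/s, with a range from 150 10^-6 cm/s to 500 10^-6 cm/s.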

Compound 4, apparent permeability: 317 10^-6 cm/s
Compound 4: middle estimate off by 1.1-fold (0.04 log units), on the low side, and the stated range covers the measured number.
By their numbers in this assay, from the lowest: compounds 3, 1, 2 and 4 (each within the scatter of the next).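

Tert-butyl in place of methoxy on an aromatic carbon, para to a large group, gives no change at the digits printed from compound 2 to compound 4 (within the scatter) in this assay. The earlier steps shown here changed the group on the saturated chain carbon and the 4-methoxyphenoxy group as a whole, whereas this step changes only the group on the ring itself, and going from 2 heavy atoms and 1 hydrogen-bond acceptor to 4 heavy atoms and 0 hydrogen-bond acceptors leaves the read-out within the scatter. No measured evidence here accounts for this result.

The exchange is shown only with the 2-hydroxy-3-methoxyphenyl group on the chain, so its outcome with the 5-fluoro-2-methoxyphenyl group of compound 1, or on the 4-methoxyphenyl series of compound 3, remains open. Methoxy and tert-butyl both carry no net charge, and the compounds shown do not tell how a carboxylic acid or an amine at this position would read in this assay.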